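The source may hold more compounds than are shown below. What is called first, only, known or untested is meant among the compounds shown, and "the series" means these compounds.

Compound 2 `Cc1cc(C)c(NC(=O)N(Cc2ccc(-c3ccn(C)n3)cc2)C2CCCCCC2)c(C)c1` is known in a functional assay on a cell-free system (plasma) with sterol O-acyltransferase, Soat (Rattus norvegicus) as the target (on this read-out lower numbers stand for an effect already at smaller amounts and higher numbers for an effect only at larger amounts of compound), only as a limit: in this assay compound 2 gives < 1 mg/kg (the limit of < 1 mg/kg in this assay, at which 1 of the 2 values shown sits). The other measured member, compound 1 `Cc1cc(C)c(NC(=O)N(Cc2ccc(N3CCN(C)CC3)cc2)C2CCCCCC2)c(C)c1`, likewise stands at a limit in this assay, > 1 mg/kg (the limit of > 1 mg/kg in this assay, at which 1 of the 2 values shown sits). Among the compounds with values here, the single measured step, a number no higher from compound 1 to compound 2 (the limit leaves the size open), therefore has no readable size. Compound 3 `Cc1cc(C)c(NC(=O)N(Cc2ccc(-c3cnn(C)c3)cc2)C2CCCCCC2)c(C)c1` differs from compound 2 by 1-methyl-1H-pyrazol-4-yl in place of 1-methyl-1H-pyrazol-3-yl on an aromatic carbon. Within the data shown here, no measured step bears directly on this change, so no step beyond the scatter is expected, a step that the limit leaves unreadable from compound 2 to compound 3. Compound 3 is thus estimated at 0.5 mg/kg in this assay, within 0.15 mg/kg to 1.5 mg/kg.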

Compound 3, dose for half-maximal effect: 0.31 mg/kg
Compound 3: middle estimate off by 1.6-fold (0.21 log units), on the high side; the measured number falls inside the stated range.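

In this assay, compound 3 gives a number rather than a limit, and at this place, para to a large group, 1-methyl-1H-pyrazol-4-yl in place of 4-methylpiperazin-1-yl brings an at least 3.2-fold lower number from compound 1 to compound 3 (0.50 log units; beyond the scatter). Compound 1 is known only as a limit, so that size is a bound: the limit of > 1 mg/kg in this assay, at which 1 of the 3 values shown sits. The step between the two methylpyrazolyl groups cannot be read, because compound 2 is known only as a limit: the limit of < 1 mg/kg in this assay, at which 1 of the 3 values shown sits.

Going by these compounds, the order of these two groups in this assay stays open. So does the effect of an unmethylated pyrazol-4-yl or a carboxylic acid at this place.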